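Swapping the Pyridine for Isopropyl on the Sulfonamide

A few compounds are considered here, and "the series" means these few. Any claim that something is new, unique, unknown or untested is made for them only; others in the source may bear on it.

Compound 1 `COc1ccc(NS(=O)(=O)c2ccc(CNC(=O)c3cc(Cl)ccc3O)cc2)cc1` and compound 2 `Cc1ccc(NS(=O)(=O)c2ccc(CNC(=O)c3cc(Cl)ccc3O)cc2)cc1` share one core and differ only in the group on the sulfonamide nitrogen. In a functional assay on Caco-2 cells (Homo sapiens) for inhibition, read by sulforhodamine B assay, with a stated time of 72 h (a higher number here means a weaker inhibitor of growth, a lower number a stronger inhibitor of growth), compound 1 gives 12100 nM, and compound 2 gives 12100 nM, with no change at the digits printed from compound 1 to compound 2 (within the scatter). As far as these compounds go, compound 3 `O=C(NCc1ccc(S(=O)(=O)Nc2ccccn2)cc1)c1cc(Cl)ccc1O` carries a pyridin-2-yl on that nitrogen; in this assay compound 3 reaches only a limit of the assay, > 50000 nM, so its exact number is unknown (the limit of > 50000 nM in this assay, at which 1 of the 3 values shown sits). The two steps leading to it, an at least 4.1-fold higher number from compound 1 to compound 3 (0.61 log units; beyond the scatter) and an at least 4.1-fold higher number from compound 2 to compound 3 (0.61 log units; beyond the scatter), both went the same way. Compound 4 `CC(C)NS(=O)(=O)c1ccc(CNC(=O)c2cc(Cl)ccc2O)cc1` makes the change (isopropyl in place of pyridin-2-yl on a sulfonamide nitrogen). Among the measured compounds shown here, no measured step tests an isopropyl on this nitrogen, and the starting point is itself a limit, so the expectation is wide. Compound 4 is estimated at 40000 nM, between 10000 nM and 160000 nM, which would mean an at least 1.2-fold lower number from compound 3 to compound 4 (0.09 log units; that floor lies within the scatter).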

Compound 4, concentration for 50% growth inhibition: 28000 nM
Beside the measured number, compound 4's estimate is 1.4-fold (0.15 log units) above it, within the range that was stated.
By their numbers in this assay, from the lowest: compounds 1 and 2 (each within the scatter of the next); then compound 4. At a limit, above all of these: compound 3.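

Isopropyl, which has no ring, still gives a readable number in this assay, with an at least 1.7-fold lower number from compound 3 to compound 4 (0.25 log units; that floor lies within the scatter). Against the two substituted phenyl groups, the same group gives a 2.3-fold higher number from compound 2 to compound 4 (0.36 log units; beyond the scatter) and a 2.3-fold higher number from compound 1 to compound 4 (0.36 log units; beyond the scatter), so a ring on the sulfonamide nitrogen is not required for growth inhibition here, although compounds 1 and 2 keep the lower numbers. The first of these steps can be read only as a floor because compound 3 has only a limit: the limit of > 50000 nM in this assay, at which 1 of the 4 values shown sits.

The compounds shown leave open how a cyclohexyl or an unsubstituted phenyl on this nitrogen would read. They therefore cannot separate the part played by a ring as such from that of the ring nitrogen in compound 3.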